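The compounds below may be only part of what the source reports. "The series", "measured", "known", "first", "only" and "open" are said of these compounds alone.

The series shares one core, seen in compound 1 `CC(=O)c1cc(C(=O)N[C@H](C)Cn2ccc(-c3cc(F)c(C#N)c(Cl)c3)n2)n[nH]1`, compound 2 `C[C@@H](Cn1ccc(-c2ccc(C#N)c(Cl)c2)n1)NC(=O)c1ccccc1F`, compound 3 `CC(=O)c1cccc(NC(=O)C(C)Cn2ccc(-c3ccc(C#N)c(Cl)c3)n2)c1` and the unmeasured compound 4 `C[C@@H](Cn1ccc(-c2ccc(C#N)c(Cl)c2)n1)Nc1nccc(Cl)n1`. Cytotoxicity is followed in an ADME assay on PC-3 cells (Homo sapiens) for cytotoxicity, read by CCK-8 assay, with a stated time of 6 days; on this read-out higher numbers stand for weaker inhibition and lower numbers for stronger inhibition. For compound 1 the outcome in this assay is "not determined" (no result reported). Compound 2 gives only a limit in this assay, > 30000 nM, so no single number is known for it. Compound 3 likewise reaches only a limit in this assay, > 30000 nM. Within the data shown here, compound 2 thus stands among the entries without a measured value, at the same limit as compound 3 (the limit of > 30000 nM in this assay, at which 2 of the 3 values shown sit), and no step between two measured compounds is available.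

The change from compound 2 to compound 4 is 4-chloropyrimidin-2-yl in place of (2-fluorophenyl)carbonyl on an amine nitrogen. Among the measured compounds shown here, with no measured step to lean on, the expectation rests only on compound 2 sitting at the limit > 30000 nM; the step in this assay is expected to be none beyond the usual scatter, and compound 4 is expected to remain at or near that limit, an estimated step of a number no higher from compound 2 to compound 4 (the limit leaves the size open). Compound 4 is therefore estimated at 30000 nM in this assay, within a range from 10000 nM to 100000 nM, most likely reported again as a limit rather than a number.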

Compound 4, half-maximal inhibitory concentration: > 30000 nM
Compound 4 ended at the assay's limit (the forecaster's own chance of this, stated with the estimate: 70%); the middle value lies on the limit itself.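

In this assay no step can be read between compound 2 and compound 4, because both end at a limit rather than at a number: the limit of > 30000 nM in this assay, at which 3 of the 4 values shown sit.

The compounds shown leave open how 4-chloropyrimidin-2-yl and (2-fluorophenyl)carbonyl compare on the amine nitrogen, and whether any compound of this series reaches a measurable value in this assay.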